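A few compounds are considered here, and "the series" means these few. Any claim that something is new, unique, unknown or untested is made for them only; others in the source may bear on it.

Compound 2 `CCn1cc(C(=O)N2N=C(c3cc4ccccc4o3)CC2c2ccc(OC)cc2O)c(=O)c2ccc(C)nc21` and compound 1 `CCn1cc(C(=O)N2N=C(c3cc4ccccc4o3)CC2c2ccccc2OC)c(=O)c2ccc(C)nc21` share one core and differ only in the group that sits on a saturated ring carbon. In an ADME assay on Vero cells (Chlorocebus sabaeus) for cytotoxicity, read by MTT assay, with a stated time of 72 h (on this read-out higher numbers stand for weaker inhibition and lower numbers for stronger inhibition), compound 2 gives a reading that is a limit of the assay, > 154000 nM. Compound 1 likewise gives only a limit in this assay, > 187000 nM. The change from compound 1 to compound 2, 2-hydroxy-4-methoxyphenyl in place of 2-methoxyphenyl, therefore gives a step that the two limits leave unreadable from compound 1 to compound 2, as the two readings sit at the limit of > 154000 nM in this assay, at which 1 of the 2 values shown sits, and (the limit of > 187000 nM in this assay, at which 1 of the 2 values shown sits). Compound 3 `CCn1cc(C(=O)N2N=C(c3cc4ccccc4o3)CC2c2ccc(O)cc2)c(=O)c2ccc(C)nc21` carries 4-hydroxyphenyl in place of 2-hydroxy-4-methoxyphenyl on a saturated ring carbon. With both measured compounds at limits, no readable step bears on this change, and no shift beyond the scatter is expected. Compound 3 is expected to give 200000 nM in this assay, between 100000 nM and 400000 nM, most likely again as a limit. The expected step from compound 2 is a step that the limit leaves unreadable from compound 2 to compound 3.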

Compound 3, half-maximal inhibitory concentration: > 148000 nM
Compound 3 was reported as a limit (the forecaster's own chance of this, stated with the estimate: 85%); the middle value does not contradict the limit.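

Compound 3, like compound 1 and compound 2, gives only a limit in this assay, so the steps among these three compounds cannot be read. The compounds shown leave open whether changing the group on the saturated ring carbon alters the reading at all.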